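Pyridine-for-phenyl step carried onto a second core

This account rests on a few compounds, and the source may have more. Where it says the series, first, only, none or still open, it means among the compounds named here.

Measured compounds in a functional assay on HepG2 cells (Homo sapiens) for antiproliferative activity, read by sulforhodamine B assay, with a stated time of 48 h; a lower number here means a stronger inhibitor, a higher number a weaker inhibitor:
compound 1, `COc1ccc(/C=C/C(=O)c2ccccc2-c2ccc(F)cc2)cc1OC`, gives 95 nM
compound 2, `COc1ccc(/C=C/C(=O)c2ccccc2-c2ccc(F)nc2)cc1OC`, gives 1000 nM
compound 3, `COc1ccc(C(=O)/C=C/c2ccccc2-c2ccc(F)cc2)cc1O`, gives 190 nM

Compound 1 and compound 2 share a core and differ in one place: 6-fluoropyridin-3-yl in place of 4-fluorophenyl on an aromatic carbon. This change produced an 11-fold higher number from compound 1 to compound 2 (1.02 log units; beyond the scatter). Compound 3 is built on a different core; the difference between the core of compound 3 and the core of compound 1 is not broken down here. In this assay compound 3 and compound 1 lie within the scatter of each other, while compound 3 and compound 2 lie beyond it.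

Compound 4, `COc1ccc(C(=O)/C=C/c2ccccc2-c2ccc(F)nc2)cc1O`, has not been measured. Among the measured compounds shown here, it differs from compound 3 as 6-fluoropyridin-3-yl in place of 4-fluorophenyl on an aromatic carbon, and the place of the change is described in the same words for both pairs, so this is the same change as the one from compound 1 to compound 2, made on a second core. For the measured compounds named here, only that one earlier instance is available, and the two cores are not the same, so how far the step transfers is uncertain. Going by the values given here, a step of roughly similar size is nevertheless expected, giving an estimated 9.5-fold higher number from compound 3 to compound 4 (0.98 log units; beyond the scatter), because the only measured instance gave an 11-fold higher number from compound 1 to compound 2 (1.02 log units; beyond the scatter). On that basis compound 4 is expected to give about 1800 nM in this assay, with a plausible range from 500 nM to 6000 nM.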

Compound 4, half-maximal inhibitory concentration: 1800 nM
Compound 4: middle estimate and measured number agree at the digits printed; the measured number falls inside the stated range.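

In this assay, 6-fluoropyridin-3-yl in place of 4-fluorophenyl again moves the series towards weaker inhibition on the second core, with a 9.5-fold higher number from compound 3 to compound 4 (0.98 log units; beyond the scatter) for the change. Two cores remain a narrow base, so this agreement does not show that the step would hold on any further core, and it does not show which feature of the change lies behind the shift or how the compounds act in the cells. Set side by side, the step keeps its size across the two cores tested here, so on these compounds it can be treated as carrying over from one core to the other: the same change on two cores in this assay, an 11-fold higher number (1.02 log units; beyond the scatter) from compound 1 to compound 2 and a 9.5-fold higher number (0.98 log units; beyond the scatter) from compound 3 to compound 4, 1.1-fold (0.05 log units) apart, within the scatter of two such steps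

The compounds shown leave open whether the step belongs to the ring nitrogen alone or depends on the fluorine that accompanies it on the new ring, and an amine, a methoxy group or a nitrile in place of that fluorine would help to separate the two. Going by these compounds, a carboxylic acid or a longer chain in place of the whole 4-fluorophenyl group also remains open, as does the question of whether any such replacement would behave alike on both cores.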